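This account rests on a few compounds, and the source may have more. Where it says the series, first, only, none or still open, it means among the compounds named here.

In a functional assay on SiHa cells (Homo sapiens) for antiproliferative activity, read by CCK-8 assay, with a stated time of 72 h (a higher number here means a weaker inhibitor, a lower number a stronger inhibitor), two compounds sharing one core have been measured so far. Compound 1 `CCSc1ccc(-c2cncnc2-c2cc(OC)c(OC)c(OC)c2)cc1` gives 1030 nM, and compound 2 `COc1cc(-c2ncncc2-c2ccc(OCC(F)(F)F)cc2)cc(OC)c1OC` gives 33300 nM, the higher of the two numbers. Going by the values given here, the only measured step, a 32-fold higher number from compound 1 to compound 2 (1.51 log units; beyond the scatter), is large and beyond the scatter, with 2,2,2-trifluoroethoxy in place of ethylsulfanyl on an aromatic carbon. Unmeasured compound 3 `COc1cc(-c2ncncc2-c2ccc(C(=O)N(C)C)cc2)cc(OC)c1OC` changes the same place, with dimethylcarbamoyl in place of 2,2,2-trifluoroethoxy on an aromatic carbon. Among the compounds with values here, the step of a 32-fold higher number from compound 1 to compound 2 (1.51 log units; beyond the scatter) shows that a change here can move the number far, but no measured compound carries dimethylcarbamoyl. Within the data shown here, with compound 2 at 33300 nM, the higher end of the numbers so far, a move to a lower number is expected, smaller than the measured step and with wide uncertainty. The expected step is a 4.2-fold lower number from compound 2 to compound 3 (0.62 log units; beyond the scatter). Compound 3 is estimated at 8000 nM, with an expected range of 1500 nM to 40000 nM.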

Compound 3, half-maximal inhibitory concentration: 20200 nM
Estimate against measurement, compound 3: 2.5-fold (0.40 log units) below; low and high end bracket the measured number.
By their numbers in this assay, from the lowest: compound 1; then compounds 3 and 2 (each within the scatter of the next).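

In this assay, the new group does not separate from the one it replaces at this aromatic carbon, para to a large group: a 1.6-fold lower number from compound 2 to compound 3 (0.22 log units; within the scatter). The large gap to ethylsulfanyl is therefore not particular to 2,2,2-trifluoroethoxy, since dimethylcarbamoyl also leaves the number well above that of compound 1, with a 20-fold higher number from compound 1 to compound 3 (1.29 log units; beyond the scatter). No measured property bears on this difference between ethylsulfanyl and the other two groups.

The compounds shown leave open whether the sulfur atom or the chain attached to it accounts for the number of compound 1, a question that ethoxy, methylsulfanyl or propylsulfanyl at this carbon would address. Also open, on these data alone, is where an amine or a carboxylic acid here would fall relative to compound 1 and the other two compounds.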